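Swapping the benzylthio substituent on a weakly active core

The source may hold more compounds than are shown below. What is called first, only, known or untested is meant among the compounds shown, and "the series" means these compounds.

Compound 1 `Cc1cc(N2CC[C@@H](C)[C@@H](N(C)c3ncnc4[nH]ccc34)C2)n2nc(SCc3ccc(C(F)(F)F)cc3)nc2n1`: 9540 nM
Compound 2 `C[C@@H]1CCN(c2cc(-c3ccccc3)nc3ncnn23)C[C@@H]1N(C)c1ncnc2[nH]ccc12`: > 100000 nM
Compound 3 `CCc1cc(N2CC[C@@H](C)[C@@H](N(C)c3ncnc4[nH]ccc34)C2)n2ncnc2n1`: > 100000 nM

Among the compounds with values here, in a functional assay on HGC-27 cells (Homo sapiens) for inhibition, read by MTT assay, with a stated time of 72 h (on this read-out lower numbers stand for stronger inhibition and higher numbers for weaker inhibition), compound 1 gives 9540 nM, the only number among the three measured compounds. Compound 2 reaches only the limit > 100000 nM. Compound 3 likewise reaches only the limit > 100000 nM. The one-point step from compound 2 to compound 3 reads a step that the two limits leave unreadable from compound 2 to compound 3, so its size is not known, which is stated by the limit of > 100000 nM in this assay, at which 2 of the 3 values shown sit. Compound 4 `Cc1cc(N2CC[C@@H](C)[C@@H](N(C)c3ncnc4[nH]ccc34)C2)n2nc(SCc3ccccc3Br)nc2n1` differs from compound 1 by 2-bromophenyl in place of 4-(trifluoromethyl)phenyl on a saturated chain carbon bound to a sulfur. Within the data shown here, no measured step touches this part of the molecule, so nothing here predicts a direction, and a step within the scatter is expected: a 1.3-fold higher number from compound 1 to compound 4 (0.10 log units; within the scatter). Compound 4 is therefore estimated at 12000 nM, between 3000 nM and 60000 nM.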

Compound 4, half-maximal inhibitory concentration: 21300 nM
For compound 4 the middle estimate is 1.8-fold (0.25 log units) below the measured one; low and high end bracket the measured number.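

Within the data shown here, putting 2-bromophenyl in place of 4-(trifluoromethyl)phenyl on a saturated chain carbon bound to a sulfur gives, in this assay, a 2.2-fold higher number from compound 1 to compound 4 (0.35 log units; beyond the scatter), the first readable step at this position, and a modest one. Both compounds still give a number rather than a limit. Nothing shown here accounts for the step.

This single step cannot separate losing the trifluoromethyl from gaining the bromine. As far as these compounds go, whether an amine or a carboxylic acid on this phenyl ring would move the number, and in which direction, remains open.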